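The compounds below may be only part of what the source reports. "The series", "measured", "known", "first", "only" and "open" are said of these compounds alone.

Measured so far:
Compound 1 `COc1ncc(-c2ccc3c(c2)N(c2ccc(C)cc2)C(=O)CO3)cc1NS(=O)(=O)c1ccc(F)cc1` gives 22700 nM in a functional assay on HCT-116 cells (Homo sapiens) for antiproliferative activity, read by MTT assay, with a stated time of 72 h; on this read-out higher numbers stand for weaker inhibition and lower numbers for stronger inhibition.
Compound 2 `O=C1COc2ccc(-c3cccc(NS(=O)(=O)c4ccc(F)cc4)c3)cc2N1C1CC1` reaches only the limit of this assay, > 40000 nM.
Compound 3 `COc1cccc(N2C(=O)COc3ccc(-c4cnc(Cl)c(NS(=O)(=O)c5ccc(F)cc5)c4)cc32)c1` likewise reaches only the limit of this assay, > 40000 nM.

For the measured compounds named here, compound 1 is the single compound here with a finished number; the other two stop at the upper limit of this assay, which is where the limit of > 40000 nM in this assay, at which 2 of the 3 values shown sit, sits. That number for compound 1 is itself a weak result, far from the strong end of the scale. Compound 4 `COc1ccc(N2C(=O)COc3ccc(-c4cnc(OC)c(NS(=O)(=O)c5ccc(F)cc5)c4)cc32)cc1` is built from compound 1 by one change: methoxy in place of methyl on an aromatic carbon. Going by the values given here, no step between two measured compounds in this set involves this group, so there is nothing measured to lean on directly. Compound 3 carries a methoxy on its ring bound to the amide nitrogen, but it also differs from compound 1 elsewhere, so its limit cannot be tied to that group alone. Swapping methyl for methoxy at the same aromatic carbon is a small change, and the expectation is for compound 4 to stay near compound 1, with the shift a 1.1-fold higher number from compound 1 to compound 4 (0.04 log units; within the scatter) inside or close to the usual scatter. Compound 4 is therefore estimated at 25000 nM, with a range from 9000 nM to 60000 nM, and a real chance that this assay reports only its limit.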

Compound 4, half-maximal inhibitory concentration: 13400 nM
Beside the measured number, compound 4's estimate is 1.9-fold (0.27 log units) above it; measured number inside the range.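

Here a single change can be read on its own for the first time: going from 4-methylphenyl to 4-methoxyphenyl in this assay gives a 1.7-fold lower number from compound 1 to compound 4 (0.23 log units; within the scatter). This position, on an aromatic carbon para to a large group, therefore takes a methoxy in place of a methyl with no shift that can be told apart from the scatter of repeated measurements, so the added oxygen, counted as one hydrogen-bond acceptor, brings no readable gain or loss here. Compound 4 also gives a finished number, as compound 1 does, while the other compounds shown remain at the assay's limit: the limit of > 40000 nM in this assay, at which 2 of the 4 values shown sit.

The compounds shown leave open whether a different group at this position, such as an amine, a carboxylic acid or a longer chain, would move the number beyond the scatter. As far as these compounds go, compound 2 and compound 3 each differ from compound 1 and compound 4 in more than one place, so it remains unknown which part of their structures separates them from this pair.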